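This account rests on a few compounds, and the source may have more. Where it says the series, first, only, none or still open, it means among the compounds named here.

Compound 1 `C/C(=C\c1cc(C2=CCCC2)co1)C(N)=O`. In a functional assay on BGC-823 cells (Homo sapiens) for cytotoxicity, read by CCK-8 assay, with a stated time of 24 h (on this read-out lower numbers stand for stronger inhibition and higher numbers for weaker inhibition), compound 1 gives > 50000 nM, which is a limit of the assay.
Compound 2 `C/C(=C\c1cc(-c2ccccc2)cs1)C(N)=O`. In this assay compound 2 gives > 50000 nM, which is a limit of the assay.
Compound 3 `C/C(=C\c1cc(-c2ccc(C)cc2)cs1)C(N)=O`. In this assay compound 3 gives > 50000 nM, which is a limit of the assay.

Compound 3 therefore stands only at a limit in this assay, and the two further values in the series are limits as well, all three sitting at one point: the limit of > 50000 nM in this assay, at which 3 of the 3 values shown sit. For the measured compounds named here, the one step between measured compounds that differ in a single place, a step that the two limits leave unreadable from compound 2 to compound 3, runs from limit to limit, so its size cannot be read.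

Compound 4 `C/C(=C\c1cc(-c2ccc(C#N)cc2)cs1)C(N)=O` differs from compound 3 by cyano in place of methyl on an aromatic carbon. Going by the values given here, the only measured step that touches the same ring position is the unreadable one just named, so no measured step gives a readable size for this change. With every value in the series at the limit, compound 4 is expected to remain near that limit, and the step that the limit leaves unreadable from compound 3 to compound 4 is expected to be no more than scatter. The estimate for compound 4 in this assay is 60000 nM, with a range from 20000 nM to 200000 nM.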

Compound 4, half-maximal inhibitory concentration: > 50000 nM
Compound 4: no number, only a limit (the forecaster's own chance of this, stated with the estimate: 80%); the middle value is on the limit's open side.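

In this assay compound 4 gives > 50000 nM, a limit of the assay. No step linking compound 4 to compound 2 or compound 3 can be read, since all values sit at one point: the limit of > 50000 nM in this assay, at which 4 of the 4 values shown sit.

The compounds shown leave open which change, if any, would bring a readable value in this assay.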